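Solubility of compound 4 from the compound 3 step

The compounds below may be only part of what the source reports. "The series", "measured", "known", "first", "only" and "open" are said of these compounds alone.

In a physicochemical assay for solubility, read by LC-MS, in phosphate buffer, with a stated time of 24 h, at pH 7.4 (a higher number here means a more soluble compound, a lower number a less soluble compound), compound 3 `CNC(=O)c1ccc(-c2cnc(NCc3c(F)ccc4c3CCO4)c3cn[nH]c(=O)c23)c(C)n1` gives 19000 nM, within the scatter of compound 2 `Cc1ncc(-c2cnc(NCc3c(F)ccc4c3CCO4)c3cn[nH]c(=O)c23)n1C` at 15000 nM. Compound 1 `Cc1nc(CO)ccc1-c1cnc(NCc2c(F)ccc3c2CCO3)c2cn[nH]c(=O)c12` gives 3000 nM, beyond the scatter from both. Compound 4 `Cc1nn(C)cc1-c1cnc(NCc2c(F)ccc3c2CCO3)c2cn[nH]c(=O)c12` carries 1,3-dimethyl-1H-pyrazol-4-yl in place of 2-methyl-6-(methylcarbamoyl)pyridin-3-yl on an aromatic carbon. The closest measured exchange, between 1,2-dimethyl-1H-imidazol-5-yl and that same pyridinyl group, is a 1.3-fold higher number from compound 2 to compound 3 (0.10 log units; within the scatter). The modest steps of a 5.0-fold higher number from compound 1 to compound 2 (0.70 log units; beyond the scatter) and a 6.3-fold higher number from compound 1 to compound 3 (0.80 log units; beyond the scatter) both start from the hydroxymethyl compound and bear less directly. No step beyond the scatter is therefore expected in this assay. The expected step is a 1.6-fold lower number from compound 3 to compound 4 (0.20 log units; within the scatter). For compound 4 the estimated value is 12000 nM, with an expected range of 4000 nM to 30000 nM.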

Compound 4, solubility: 9000 nM
Compound 4: the middle estimate sits 1.3-fold (0.12 log units) above what was measured; the range from low to high includes it.
By their numbers in this assay, from the lowest: compound 1; then compounds 4, 2 and 3 (each within the scatter of the next, the first and the last beyond it).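

In this assay, 1,3-dimethyl-1H-pyrazol-4-yl in place of 2-methyl-6-(methylcarbamoyl)pyridin-3-yl gives a 2.1-fold lower number from compound 3 to compound 4 (0.32 log units; beyond the scatter) at this position, so not every five-membered aromatic ring here stays within the scatter of the pyridinyl amide. The two five-membered rings remain together, with a 1.7-fold lower number from compound 2 to compound 4 (0.22 log units; within the scatter) on exchanging 1,2-dimethyl-1H-imidazol-5-yl for the pyrazolyl group. The hydroxymethyl compound stays apart, with a 3.0-fold higher number from compound 1 to compound 4 (0.48 log units; beyond the scatter) even though the entering group has 0 hydrogen-bond donors.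

Going by these compounds, an aminomethyl group, a carboxylic acid or a longer chain on the pyrazole nitrogen remains open at this position. Nothing available here explains the size of these steps.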